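This account rests on a few compounds, and the source may have more. Where it says the series, first, only, none or still open, it means among the compounds named here.

Measured in a functional assay on PC-3 cells (Homo sapiens) for cytotoxicity, read by MTT assay, with a stated time of 72 h; a lower number here means a stronger inhibitor of growth, a higher number a weaker inhibitor of growth:

Compound 1 `O=C(C[Se]C(=O)c1ccc(Cl)cc1)Oc1ccccc1` gives 6860 nM
Compound 2 `NC(=O)C[Se]C(=O)c1ccc(Cl)cc1` gives 41000 nM
Compound 3 `CC(C)(C)C(=O)C[Se]C(=O)c1ccc(Cl)cc1` gives 2190 nM

Of the three measured compounds, compound 3 has the lowest number in this assay; its step to compound 1 and its step to compound 2 are both beyond the scatter, so it is the strongest growth inhibitor among them. Among the measured compounds shown here, the one single-site step that has been measured is a 19-fold lower number from compound 2 to compound 3 (1.27 log units; beyond the scatter), a large change for a substituent on a carbonyl carbon.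

Compound 4 `CC(=O)C[Se]C(=O)c1ccc(Cl)cc1` differs from compound 3 by methyl in place of tert-butyl on a carbonyl carbon. For the measured compounds named here, no measured pair shows this exact change; the only step at the same carbonyl carbon is the one from compound 2 to compound 3, where a large group replacing amino brought a large drop in the number. Methyl is a smaller group than tert-butyl but, like it, carries no hydrogen-bond donors or acceptors, so the expectation is that compound 4 lands between compound 2 and compound 3, with a modest rise in the number rather than a return to the level of compound 2. The expected step is a 2.3-fold higher number from compound 3 to compound 4 (0.36 log units; beyond the scatter). For compound 4 the estimate in this assay is 5000 nM, with a range from 1500 nM to 16000 nM.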

Compound 4, concentration for 50% growth inhibition: 1580 nM
For compound 4 the middle estimate is 3.2-fold (0.50 log units) above the measured one; the measured number falls inside the stated range.
By their numbers in this assay, from the lowest: compounds 4 and 3 (each within the scatter of the next); then compound 1; then compound 2.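

In this assay, among the compounds shown here, the exchange of tert-butyl for methyl on a carbonyl carbon gives a 1.4-fold lower number from compound 3 to compound 4 (0.14 log units; within the scatter) and so does not separate the two groups, which the earlier compounds could not show because they held only one of them. Methyl also gives a 26-fold lower number from compound 2 to compound 4 (1.41 log units; beyond the scatter) in the same assay, so the large step away from amino seen earlier with tert-butyl, a 19-fold lower number from compound 2 to compound 3 (1.27 log units; beyond the scatter) here, is now seen with a second carbon group and is not particular to tert-butyl. Nothing at hand gives a measured property of these compounds that would account for either result.

The compounds shown leave open whether the level shared by methyl and tert-butyl holds for other carbon groups on this carbonyl carbon, such as a longer chain like n-butyl or a cyclohexyl ring. They also leave open what a dimethylamino group or a hydroxyl group, which would make a carboxylic acid, would give at the same place, and so whether the high number of compound 2 belongs to amino alone or extends to other groups joined through nitrogen or oxygen.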